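The source may hold more compounds than are shown below. What is called first, only, known or untested is meant among the compounds shown, and "the series" means these compounds.

Measured so far in an assay on microsomes from liver for inhibition of 3-hydroxy-3-methylglutaryl-coenzyme A reductase (Rattus norvegicus); a higher number here means a weaker inhibitor, a lower number a stronger inhibitor:
Compound 1, `Cc1ccccc1CNC(=O)c1nn(-c2ccc(F)cc2)c(OC[C@@H](O)C[C@@H](O)CC(=O)O)c1C(C)C`, gives 17 nM.
Compound 2, `COc1ccc(CNC(=O)c2nn(-c3ccc(F)cc3)c(OC[C@@H](O)C[C@@H](O)CC(=O)O)c2C(C)C)cc1`, gives 12 nM.

For the measured compounds named here, compound 2 stands at the lower of the two numbers, and its only neighbour is compound 1, with a step of a 1.4-fold lower number from compound 1 to compound 2 (0.15 log units; within the scatter), so the two are not separated beyond the scatter. The next compound, compound 3, `COc1ccccc1CNC(=O)c1nn(-c2ccc(F)cc2)c(OC[C@@H](O)C[C@@H](O)CC(=O)O)c1C(C)C`, arises from compound 2 by the change (2-methoxyphenyl in place of 4-methoxyphenyl on a saturated chain carbon bound to an amide-type nitrogen). Going by the values given here, only one measured step bears on this: the step from compound 1 to compound 2, where 2-methylphenyl gave way to 4-methoxyphenyl at the same saturated chain carbon, and that step stayed within the scatter. Among the compounds with values here, no measured pair moves a methoxy group around the ring on its own. The step from compound 2 to compound 3 is therefore expected to be small in this assay, around a 1.3-fold higher number from compound 2 to compound 3 (0.10 log units; within the scatter), with no clear direction. Compound 3 is estimated at 15 nM, in the range 6 nM to 40 nM.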

Compound 3, half-maximal inhibitory concentration: 22 nM
For compound 3 the middle estimate is 1.5-fold (0.17 log units) below the measured one; the measured number falls inside the stated range.
By their numbers in this assay, from the lowest: compounds 2, 1 and 3 (each within the scatter of the next).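

In this assay, for the compounds shown here, moving the methoxy group from 4-methoxyphenyl to 2-methoxyphenyl on the saturated chain carbon bound to the amide-type nitrogen is the first measured change of this kind, and it stays within the scatter, with a 1.8-fold higher number from compound 2 to compound 3 (0.26 log units; within the scatter). Methoxy in place of methyl on an aromatic carbon also stays within the scatter, with a 1.3-fold higher number from compound 1 to compound 3 (0.11 log units; within the scatter), so among these three compounds neither the place of the methoxy group nor the choice of methoxy or methyl separates the numbers. Nothing at hand speaks to a cause for these results.

These compounds carry only methoxy or methyl on this aromatic ring. Going by these compounds, whether an amine or a carboxylic acid on that ring, or a longer chain in place of the benzyl group, would move the number beyond the scatter remains open.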